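The source may report more compounds than this note shows. Statements on the series, on what has been measured and on what is new or still open speak of the compounds shown alone.

Three close relatives have been run in a functional assay on PC-3 cells (Homo sapiens) for cytotoxicity, read by sulforhodamine B assay, with a stated time of 48 h; on this read-out lower numbers stand for stronger inhibition of growth and higher numbers for weaker inhibition of growth. Compound 1 `Nc1nc(Cl)c2ncn(Cc3ccccc3CCl)c2n1` carries an amino group on its core, and in this assay compound 1 gives 67600 nM, the highest of the three numbers, so it is the weakest of the group. Compound 2 `Nc1nc(Cl)c2ncn(Cc3ccc(CCl)cc3)c2n1` moves the chloromethyl group on the benzyl arm to another position, and in this assay compound 2 gives 25100 nM, a gap to compound 1 that lies beyond the scatter. Compound 3 `ClCc1ccccc1Cn1cnc2ncnc(Cl)c21` keeps the arm of compound 1 but lacks the amino group, and in this assay compound 3 gives 19100 nM, the lowest number of the three, again beyond the scatter from compound 1.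

Compound 4 `ClCc1ccccc1Cn1cnc2c(Cl)nc(Cl)nc21` has not yet been measured. It differs from compound 1 in one place: chloro in place of amino on an aromatic carbon. The only hint available is that compound 3, which also does without the amino group at that place, gives 19100 nM, lower than compound 1. On that basis the step from compound 1 to compound 4 in this assay is expected to be a modest move toward stronger growth inhibition, around a 3.1-fold lower number from compound 1 to compound 4 (0.49 log units; beyond the scatter), though it may fall within the scatter. The expected value for compound 4 is therefore 22000 nM, with a range from 7000 nM to 65000 nM.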

Compound 4, concentration for total growth inhibition: 1620 nM
Beside the measured number, compound 4's estimate is 14-fold (1.13 log units) above it, and the stated range ends above it.
By their numbers in this assay, from the lowest: compound 4; then compounds 3 and 2 (each within the scatter of the next); then compound 1.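

In this assay, among these compounds, putting chloro in place of amino on this aromatic carbon, the one between two ring nitrogen atoms, gives a 42-fold lower number from compound 1 to compound 4 (1.62 log units; beyond the scatter) and so counts as a large step, which the earlier compounds gave no sign of. Losing the amino group is not the whole story: compound 3, which has only a hydrogen at this place, gives 19100 nM while compound 4 gives 1620 nM and so the lower number goes with chloro present, not merely with amino absent. No measurement shown here gives a reason for the size of this step.

The compounds shown leave open whether other groups at this place, such as bromo, methyl or methoxy, would reach a number as low as chloro does, or whether chloro stands alone. They also leave open whether the same swap would give a step of similar size on the arm of compound 2, since the one step shown carries the arm of compound 1.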